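This account rests on a few compounds, and the source may have more. Where it says the series, first, only, none or still open, it means among the compounds named here.

Series notes on the shared core of compound 1 `COc1ccc(C)cc1-c1c(C)nn(-c2nc(-c3ccc(Cl)c(Cl)c3)c(SC(C)C)s2)c1C(=O)O`. Within the data shown here, in a functional assay on BJAB cells (Homo sapiens) for antiproliferative activity, with a stated time of 4 days (a lower number here means that less compound is needed, a higher number that more compound is needed for the effect), compound 1 gives 9500 nM, the second highest of the three numbers so far. Compound 2 `Cc1ccccc1-c1c(C)nn(-c2nc(-c3ccc(Cl)c(Cl)c3)c(SC(C)C)s2)c1C(=O)O` gives 5500 nM in this assay, and compound 3 `COc1ccccc1-c1c(C)nn(-c2nc(-c3ccc(Cl)c(Cl)c3)c(SC(C)C)s2)c1C(=O)O` gives 14700 nM. Among the measured compounds shown here, the step of a 1.7-fold lower number from compound 1 to compound 2 (0.24 log units; within the scatter) and the step of a 1.5-fold higher number from compound 1 to compound 3 (0.19 log units; within the scatter) both stay within the scatter; only the step of a 2.7-fold higher number from compound 2 to compound 3 (0.43 log units; beyond the scatter) reaches beyond it, and modestly. All three measured compounds carry a six-membered aromatic ring of carbon only on the same aromatic carbon of the core, so the measured steps speak only to substituents on that ring.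

Compound 4 `Cc1nn(-c2nc(-c3ccc(Cl)c(Cl)c3)c(SC(C)C)s2)c(C(=O)O)c1-c1ccncc1` takes a different direction: pyridin-4-yl in place of 2-methoxy-5-methylphenyl on an aromatic carbon. For the measured compounds named here, no measured pair exchanges the six-membered aromatic ring of carbon only for a ring with a hetero atom, so none of the three steps bears directly on this change; they show only that variation at this place has moved this assay within a narrow band, the widest being the step from compound 2 to compound 3. On that basis a step no larger than the scatter is expected in this assay, with no direction preferred. Compound 4 is therefore estimated at 10000 nM in this assay, within 3000 nM to 35000 nM, which means the expected step of a 1.1-fold higher number from compound 1 to compound 4 (0.02 log units; within the scatter).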

Compound 4, half-maximal effective concentration: 5900 nM
Estimate against measurement, compound 4: 1.7-fold (0.23 log units) above, and the stated range covers the measured number.
By their numbers in this assay, from the lowest: compounds 2, 4, 1 and 3 (each within the scatter of the next, the first and the last beyond it).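

Among these compounds, the first measured exchange of the six-membered aromatic ring of carbon only for a ring with a hetero atom leaves this assay in the same band: both a 1.6-fold lower number from compound 1 to compound 4 (0.21 log units; within the scatter) and a 1.1-fold higher number from compound 2 to compound 4 (0.03 log units; within the scatter) stay within the scatter, even though the entering pyridin-4-yl has 6 heavy atoms against the 9 of the leaving 2-methoxy-5-methylphenyl. Among the compounds shown here, the one step beyond the scatter, and only modestly so, is a 2.5-fold lower number from compound 3 to compound 4 (0.40 log units; beyond the scatter) and this places compound 4 level with compound 2 in its distance from compound 3, so at this position neither a ring of carbon only nor the substituents on it appear to be required for the read-out. No supporting data accompany these numbers, and the steps therefore remain without an assigned explanation.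

The compounds shown leave open whether the place of the ring nitrogen matters, as pyridin-2-yl or pyridin-3-yl would show, and whether a five-membered aromatic ring such as thiazolyl fits the same band. Also open, going by these compounds, is whether a basic amine such as piperidinyl, or a carboxylic acid on the ring, would move this position beyond the narrow band seen so far.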